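The source may report more compounds than this note shows. Statements on the series, on what has been measured and on what is new or still open speak of the compounds shown alone.

Within the data shown here, compound 2 `COc1ccc(CNC(=O)c2cc(Oc3ccc(/C=C/c4ccncc4)cc3)ccn2)cc1` is one of only two compounds so far measured in a functional assay on A549 cells (Homo sapiens) for antiproliferative activity, read by CCK-8 assay, with a stated time of 48 h; a higher number here means a weaker inhibitor, a lower number a stronger inhibitor; in this assay compound 2 gives 19300 nM. The other, compound 1 `O=C(NCc1ccccc1)c1cc(Oc2ccc(/C=C/c3ccncc3)cc2)ccn1`, gives 17000 nM in this assay, and the step of a 1.1-fold higher number from compound 1 to compound 2 (0.06 log units; within the scatter) leaves the two values within the scatter of each other, so neither can be called the stronger. Compound 3 `CC(C)NC(=O)c1cc(Oc2ccc(/C=C/c3ccncc3)cc2)ccn1` has not yet been measured in this assay. Compared with compound 2 it carries isopropyl in place of 4-methoxybenzyl on an amide-type nitrogen. Among the measured compounds shown here, the single measured step, a 1.1-fold higher number from compound 1 to compound 2 (0.06 log units; within the scatter), concerns a methoxy in place of hydrogen on an aromatic carbon and changed nothing beyond the scatter, so it says little about a change that removes the whole 4-methoxybenzyl and puts isopropyl on the amide-type nitrogen. For the measured compounds named here, no measured pair shows what this assay makes of a group without a ring at that place. On that basis compound 3 is expected to give 30000 nM in this assay, with a range from 10000 nM to 100000 nM. The step of a 1.6-fold higher number from compound 2 to compound 3 (0.19 log units; within the scatter) that this estimate implies is expected to be small and uncertain in direction.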

Compound 3, half-maximal inhibitory concentration: 20600 nM
The estimate for compound 3 lay 1.5-fold (0.16 log units) above the measured number, and the stated range covers the measured number.
By their numbers in this assay, from the lowest: compounds 1, 2 and 3 (each within the scatter of the next).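

In this assay the group on the amide-type nitrogen now has no ring at all, and both the step of a 1.1-fold higher number from compound 2 to compound 3 (0.03 log units; within the scatter) and the step of a 1.2-fold higher number from compound 1 to compound 3 (0.08 log units; within the scatter) lie within the scatter. The earlier pair differed only by a methoxy on the aromatic ring of the benzyl group, whereas these steps exchange the entire group: at this place, isopropyl, with 3 heavy atoms and no ring, cannot be told apart from either benzyl or 4-methoxybenzyl, with its 9 heavy atoms and its ring. Nothing among the available data accounts for this result.

On these data alone, it remains open whether any group at this place could give a number beyond the scatter, for instance a longer chain ending in an amine or a carboxylic acid, or a methyl group in place of the amide hydrogen. All three compounds share the same core and differ only in the group on the amide-type nitrogen, so they leave open how this assay would respond to a change anywhere else in the structure.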